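The source may hold more compounds than are shown below. What is called first, only, known or untested is meant among the compounds shown, and "the series" means these compounds.

Three compounds have been measured so far:

Compound 1, `CC(C(=O)N1CCN(c2ccc(F)cc2)CC1)N1C(=O)CCC1=O` — in a functional assay on the whole organism (strain Swiss) with Mus musculus as the target, in the maximal electroshock model, with a stated time of 2 h, at a dose of 300 mg/kg by the intraperitoneal route (a higher number here means a stronger effect of the compound at the dose given, a lower number a weaker effect), compound 1 gives 50%.
Compound 2, `CCC(C(=O)N1CCN(c2cccc(C)c2)CC1)N1C(=O)CCC1=O` — in this assay compound 2 gives 0%.
Compound 3, `CC(C(=O)N1CCN(c2ccccc2Cl)CC1)N1C(=O)CCC1=O` — in this assay compound 3 gives 0%.

Compound 3 stands level with compound 2 at the digits reported; together they hold the lowest numbers of the three. Going by the values given here, the only measured neighbour of compound 3 that differs in one place is compound 1, and that step, a number 50 percentage points lower from compound 1 to compound 3 (beyond the scatter), is large.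

The next compound, compound 4, `Cc1cccc(N2CCN(C(=O)C(C)N3C(=O)CCC3=O)CC2)c1`, is made from compound 3 by one change: 3-methylphenyl in place of 2-chlorophenyl on an amine nitrogen in a ring

Among the compounds with values here, the single measured step bearing on the aromatic group on this ring nitrogen is the one from compound 1 to compound 3, and it shows that swapping this group can move the read-out a long way. The group that enters in compound 4 is the same 3-methylphenyl that compound 2 carries, though compound 2 has a longer chain on the carbon bearing the amide carbonyl, and compound 2 gives 0%. Taken together, compound 4 is expected to stay near the low end, a step of a number 8 percentage points higher from compound 3 to compound 4 (within the scatter), which is within the scatter. The estimate for compound 4 is 8%, with a range from 0% to 35%.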

Compound 4, a percentage reported as activity, at one dose (the size of the read-out at that dose, not a potency): 0%
For compound 4 the middle estimate is 8 percentage points above the measured one, and the stated range covers the measured number.
By their numbers in this assay, from the lowest: compounds 2, 3 and 4 (each within the scatter of the next); then compound 1.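

In this assay, the swap of 2-chlorophenyl for 3-methylphenyl gives no change at the digits printed from compound 3 to compound 4 (within the scatter) and so separates nothing, while the same position gives a number 50 percentage points lower from compound 1 to compound 4 (beyond the scatter) when 3-methylphenyl replaces 4-fluorophenyl. Among the three aromatic groups shown on this ring nitrogen with the shorter chain, only 4-fluorophenyl therefore stands apart, and the two other groups cannot be told apart despite having different substituents. Going by these compounds alone, the chain can also be read for the first time, with no change at the digits printed from compound 2 to compound 4 (within the scatter), but this pair carries 3-methylphenyl and shows nothing about the chain's effect alongside 4-fluorophenyl, and nothing available explains why the aromatic groups behave this way.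

Going by these compounds, whether the result of compound 1 follows the fluorine itself or its place on the aromatic ring stays open, and a 4-chlorophenyl, 4-methylphenyl or 2-fluorophenyl group on the ring nitrogen would help to separate the two. On these data alone, it also remains open whether the read-out of compound 1 would survive a longer chain on the carbon bearing the amide carbonyl, as in compound 2.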